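This account rests on a few compounds, and the source may have more. Where it says the series, first, only, none or still open, it means among the compounds named here.

Measured so far:
compound 1 `N#CC1=C(NCN2CCCC2)N(c2ccccc2)C(=O)N2CCCCC(N3CCCC3)C12` 26.6%
compound 2 `N#CC1=C(NCC(=O)N2CCCC2)N(c2ccccc2)C(=O)N2CCCCC(N3CCCC3)C12` 49.8%
compound 3 `N#CC1=C(/N=C/c2ccccc2)N(c2ccccc2)C(=O)N2CCCCC(N3CCCC3)C12` 75.9%

In a functional assay on the whole organism (strain albino) for inhibition, with Rattus norvegicus as the target, read by paw edema, with stated times of 1 h and 2 h, at a dose of 20 mmol/kg by the intraperitoneal route (on this read-out higher numbers stand for more inhibition at the one dose given (going by the name of the read-out) and lower numbers for less inhibition), compound 3 stands highest of the three numbers, with compound 2 nearest and compound 1 furthest; both gaps are beyond the scatter. Compound 4 `N#CC1=C(NC(=O)c2ccccc2O)N(c2ccccc2)C(=O)N2CCCCC(N3CCCC3)C12` differs from compound 3 in one place: a group of 10 heavy atoms (7 carbon, 1 nitrogen, 2 oxygen; one six-membered aromatic ring of carbon only) in place of a group of 8 heavy atoms (7 carbon, 1 nitrogen; one six-membered aromatic ring of carbon only), on a double-bonded ring carbon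

Among the measured compounds shown here, the steps that bear on this change are those that alter the same carbon. The step of a number 49.3 percentage points higher from compound 1 to compound 3 (beyond the scatter) and the step of a number 26.1 percentage points higher from compound 2 to compound 3 (beyond the scatter) both show the aromatic ring on that carbon going with the higher numbers, and compound 4 keeps such a ring. The step of a number 23.2 percentage points higher from compound 1 to compound 2 (beyond the scatter) shows that a carbonyl entering on a chain bound to the amine nitrogen raised the number. For the measured compounds named here, on these three steps compound 4 is expected to stay well above compound 1 and compound 2, but the loss of the double bond outside the ring that compound 3 carries gives no measured precedent, so a modest downward step is estimated: a number 13.9 percentage points lower from compound 3 to compound 4 (beyond the scatter). Compound 4 is thus expected at 62%, within a range of 42% to 80%, in this assay.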

Compound 4, a percentage reported as inhibition, in the whole organism at one dose (the size of the read-out at that dose, not a potency): 53.8%
Compound 4: middle estimate off by 8.2 percentage points, on the high side; the range from low to high includes it.
By their numbers in this assay, from the lowest: compound 1; then compounds 2 and 4 (each within the scatter of the next); then compound 3.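

In this assay, the change at the double-bonded ring carbon reads as a number 22.1 percentage points lower from compound 3 to compound 4 (beyond the scatter), so keeping a six-membered aromatic ring of carbon only in the group there does not by itself hold the number of compound 3. Set against the two amine chains, (2-hydroxyphenyl)carbonyl gives a number 4 percentage points higher from compound 2 to compound 4 (within the scatter) and a number 27.2 percentage points higher from compound 1 to compound 4 (beyond the scatter), so it stands level with ((pyrrolidin-1-yl)carbonyl)methyl and clear of (pyrrolidin-1-yl)methyl. Nothing measured here accounts for these steps.

The compounds shown leave open whether the fall from compound 3 goes with the carbonyl or with the hydroxyl, and a plain benzoyl group or a 2-hydroxybenzylidene group at this place would separate the two. Going by these compounds, how a morpholine on the chain would compare also remains open.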